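The source may hold more compounds than are shown below. What is called first, only, known or untested is meant among the compounds shown, and "the series" means these compounds.

Measured compounds:
compound 1 `CNC(=S)N/N=C1\C(=O)Nc2ccccc21`: in an ADME assay on RD cells (Homo sapiens) for cytotoxicity (on this read-out lower numbers stand for higher toxicity in this test and higher numbers for lower toxicity in this test), compound 1 reaches only a limit of the assay, > 25000 nM.
compound 2 `O=C1Nc2ccccc2/C1=N/NC(=S)N1CCCC1`: in this assay compound 2 likewise reaches only a limit of the assay, > 25000 nM.
compound 3 `O=C1Nc2ccccc2/C1=N/NC(=S)N1CCCCC1`: in this assay compound 3 also reaches only a limit of the assay, > 25000 nM.

Compound 3 thus stands where every measured member of the series stands, at the limit of > 25000 nM in this assay, at which 3 of the 3 values shown sit. No number is available for it, only the limit. The three measured steps, a step that the two limits leave unreadable from compound 1 to compound 2, a step that the two limits leave unreadable from compound 1 to compound 3 and a step that the two limits leave unreadable from compound 2 to compound 3, are all unreadable because at both ends the value sits at the limit of > 25000 nM in this assay, at which 3 of the 3 values shown sit. Nothing can be said about their size or direction.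

Compound 4 `CCCNC(=S)N/N=C1\C(=O)Nc2ccccc21` differs from compound 3 in one place: propylamino in place of piperidin-1-yl on a thiocarbonyl carbon. This is the same kind of exchange as the three measured ones, a change of the amine attached to the thiocarbonyl carbon while the shared core of compound 3 stays untouched. Methylamino, pyrrolidin-1-yl and piperidin-1-yl all left the read-out at the limit, so there is no basis for expecting a readable step here either.

Compound 4 is expected to sit at the limit as well, with an estimate of 25000 nM and a range of 12000 nM to 60000 nM. The step of a number no higher from compound 3 to compound 4 (the limit leaves the size open) is expected to be none beyond the scatter.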

Compound 4, half-maximal cytotoxic concentration: > 25000 nM
Compound 4 ended at the assay's limit; the forecaster's own chance of this, stated with the estimate: 85%; the middle value lies on the limit itself.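

Compound 4 joins compound 1, compound 2 and compound 3 at the same limit in this assay, so none of its steps to those three compounds can be read, in size or in direction, because every value sits at one limit: the limit of > 25000 nM in this assay, at which 4 of the 4 values shown sit.

The compounds shown leave open how far each one lies past that limit, and whether exchanging the amine on the thiocarbonyl carbon changes the read-out at all.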